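The compounds below may be only part of what the source reports. "The series", "measured", "known", "first", "only" and "open" are said of these compounds alone.

Three compounds built on one shared core have been examined in a functional assay on WI-38 VA13 cells (Homo sapiens) for cytotoxicity; a higher number here means that more compound is needed for the effect, a lower number that less compound is needed. Compound 1 `N#Cc1cccc(C(=O)Nc2ccc3nc(NC(=O)C4CCCCC4)sc3c2)c1` gives 0.52 ug/mL, the lowest of the three numbers. Compound 2 `CC(=O)Nc1ccc2nc(NC(=O)C3CCCCC3)sc2c1` gives 2.7 ug/mL, and compound 3 `CCC(C)(C)C(=O)Nc1ccc2nc(NC(=O)C3CCCCC3)sc2c1` gives 1 ug/mL. Each of them differs from compound 1 only on a carbonyl carbon. The measured steps there are a 5.2-fold higher number from compound 1 to compound 2 (0.72 log units; beyond the scatter) and a 1.9-fold higher number from compound 1 to compound 3 (0.28 log units; within the scatter). Compound 4 `Cc1cc(C(=O)Nc2ccc3nc(NC(=O)C4CCCCC4)sc3c2)n(C)n1` changes the same carbonyl carbon: 1,3-dimethyl-1H-pyrazol-5-yl in place of 3-cyanophenyl on a carbonyl carbon. The two measured steps on this carbonyl carbon both raised the number in this assay, one beyond the scatter and one within it, so a small rise is expected for compound 4, a 1.7-fold higher number from compound 1 to compound 4 (0.24 log units; within the scatter). The value of compound 4 in this assay is estimated at 0.9 ug/mL, within a range of 0.35 ug/mL to 2.5 ug/mL.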

Compound 4, half-maximal effective concentration: 0.12 ug/mL
The estimate for compound 4 lay 7.5-fold (0.88 log units) above the measured number; the whole stated range lies above it.
By their numbers in this assay, from the lowest: compound 4; then compounds 1 and 3 (each within the scatter of the next); then compound 2.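

In this assay the step to 1,3-dimethyl-1H-pyrazol-5-yl is a 4.3-fold lower number from compound 1 to compound 4 (0.64 log units; beyond the scatter) and so the first measured replacement of 3-cyanophenyl on this carbonyl carbon that lowers the number. Within the data shown here, the same group gives an 8.3-fold lower number from compound 3 to compound 4 (0.92 log units; beyond the scatter) and a 23-fold lower number from compound 2 to compound 4 (1.35 log units; beyond the scatter) against 1,1-dimethylpropyl and methyl, so this position moves the number further than the earlier compounds showed. No evidence at hand accounts for this drop. Going by these compounds, what remains open is how a carboxylic acid, an amine or a pyrazole ring without its two methyl groups would behave on this carbonyl carbon.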